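Removing a Methyl from an Aromatic Oxygen: Expected Cytotoxicity

The source may report more compounds than this note shows. Statements on the series, on what has been measured and on what is new or still open speak of the compounds shown alone.

Compound 1, `Cc1cc(O)cc(-c2nn(CC#N)cc2-c2ccnc(-c3ccc(Oc4ccccc4)cc3)c2)c1`: 96%
Compound 2, `COc1cc(C)cc(-c2nn(CC#N)cc2-c2ccnc(-c3ccc(N(C)C)cc3)c2)c1`: 97%

Of the compounds shown here, two have so far been tested in a functional assay on CCRF-CEM cells (Homo sapiens) for cytotoxicity, read by sulforhodamine B assay, with a stated time of 48 h, tested at 0.001 uM; a lower number here means a stronger effect, a higher number a weaker effect of the compound at the concentration tested. Compound 1 gives 96% in this assay, and compound 2 gives 97%. The gap between the two numbers lies within the usual scatter of repeated measurements, so compound 2 stands where compound 1 stands, and both show only a weak effect at the concentration tested. Compound 2 is the starting point for the next step.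

Compound 3, `Cc1cc(O)cc(-c2nn(CC#N)cc2-c2ccnc(-c3ccc(N(C)C)cc3)c2)c1`, has not yet been measured. It differs from compound 2 in a single place: hydrogen in place of methyl on an oxygen on an aromatic ring. Cut one bond further out, the change reads methoxy to hydroxy, so the 3-methoxy-5-methylphenyl group of compound 2 becomes the 3-hydroxy-5-methylphenyl group that compound 1 already carries.

Going by the values given here, no pair of measured compounds isolates this change. Compound 1 carries the hydroxy group and compound 2 the methoxy group, and their values are alike within the scatter, though the two compounds also differ elsewhere. The expectation for compound 3 is therefore a step of a number 1 percentage points lower from compound 2 to compound 3 (within the scatter) that stays within the scatter, with no direction claimed. Compound 3 is estimated at 96%, in the range 86% to 102%.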

Compound 3, a percentage reported as activity, at one concentration (the size of the read-out at that concentration, not a potency): 97%
The estimate for compound 3 lay 1 percentage points below the measured number; the measured number falls inside the stated range.
By their numbers in this assay, from the lowest: compounds 1, 2 and 3 (each within the scatter of the next).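

Going by these compounds alone, for the first time, a pair of compounds isolates the swap of methoxy for hydroxy, turning the 3-methoxy-5-methylphenyl group into the 3-hydroxy-5-methylphenyl group, and in this assay this single change gives no change at the digits printed from compound 2 to compound 3 (within the scatter), so at this concentration the read-out does not tell the two groups apart. A second single-place comparison now exists at the far end of the molecule, where dimethylamino in place of phenoxy on an aromatic carbon gives a number 1 percentage points higher from compound 1 to compound 3 (within the scatter), and this exchange is not told apart either. The compounds offer no measured information that could explain these results, whether about the groups themselves or about how the cells respond to them.

All three compounds show only a weak effect at this one low concentration, so the read-out says nothing about how they would compare at higher concentrations, where differences might appear. Also open, as far as these compounds go, is whether a longer chain on the oxygen, such as ethoxy, or an amine in place of the hydroxy would give a value that stands apart from these.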